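From a Propyl Urea to a Bulky Aryl Urea

This account rests on a few compounds, and the source may have more. Where it says the series, first, only, none or still open, it means among the compounds named here.

Among the compounds with values here, compound 2 `CCCNC(=O)N1CCN(c2ncnc3sc(-c4ccc(N5CCN(C)CC5)cc4)cc23)CC1` gives the lower of the two numbers measured so far. In a functional assay on MDA-MB-231 cells (Homo sapiens) for antiproliferative activity, read by MTT assay, with a stated time of 48 h (on this read-out lower numbers stand for stronger inhibition and higher numbers for weaker inhibition), compound 2 gives 8330 nM, while compound 1 `C=CS(=O)(=O)N1CCN(c2ncnc3sc(-c4cccc5ncccc45)cc23)CC1` gives 21000 nM, a gap beyond the usual scatter. Compound 3 `CC(C)c1cccc(C(C)C)c1NC(=O)N1CCN(c2ncnc3sc(-c4ccc(N5CCN(C)CC5)cc4)cc23)CC1` is the next step: 2,6-diisopropylphenyl in place of propyl on an amide-type nitrogen. Within the data shown here, no measured pair shows a change of this kind, so the direction is open; the expected step of a 1.2-fold higher number from compound 2 to compound 3 (0.08 log units; within the scatter) is small, if anything toward a weaker value. Compound 3 is therefore expected at 10000 nM, within a range from 3000 nM to 35000 nM.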

Compound 3, half-maximal inhibitory concentration: 8430 nM
Estimate against measurement, compound 3: 1.2-fold (0.07 log units) above; the range from low to high includes it.
By their numbers in this assay, from the lowest: compounds 2 and 3 (each within the scatter of the next); then compound 1.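

In this assay the swap of propyl for 2,6-diisopropylphenyl on the amide-type nitrogen gives a 1.0-fold higher number from compound 2 to compound 3 (0.01 log units; within the scatter) and so leaves the read-out within the scatter. This first single-change pair shows that a group of 12 heavy atoms with an aromatic ring reads the same here as a chain of 3 heavy atoms. No measurement at hand offers an explanation for this.

Going by these compounds, whether an amine, a carboxylic acid or a longer chain such as octyl on this nitrogen would shift the number remains open. So does whether a smaller aryl group, plain phenyl, would read the same.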